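The source may report more compounds than this note shows. Statements on the series, on what has been measured and on what is new or still open speak of the compounds shown alone.

Compound 1 `CC(C)N(C)c1ccc2cc(NC(=O)CCc3ccc(C(F)(F)F)cc3)ccc2n1` gives 140 nM in a functional assay on HEK293 cells for activation of melanin-concentrating hormone receptor 1 (Rattus norvegicus), read by inositol phosphate accumulation; a lower number here means that less compound is needed, a higher number that more compound is needed for the effect.
Compound 2 `O=C(CCc1ccc(C(F)(F)F)cc1)Nc1ccc2nc(N3CC4CC3CN4)ccc2c1` gives 490 nM in this assay.
Compound 3 `O=C(CCc1ccc(C(F)(F)F)cc1)Nc1ccc2nc(N3CCC(c4ccccc4)C3)ccc2c1` gives 1770 nM in this assay.

Compound 3 has the highest number of the three. Against its nearest neighbour it shows a 3.6-fold higher number from compound 2 to compound 3 (0.56 log units; beyond the scatter), and against its furthest it shows a 13-fold higher number from compound 1 to compound 3 (1.10 log units; beyond the scatter). All three compounds share the same amide-linked core and differ only in the amine group attached next to the ring nitrogen of that core.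

Compound 4 `O=C(CCc1ccc(C(F)(F)F)cc1)Nc1ccc2nc(N3CCCCCC3)ccc2c1` has not yet been measured. It differs from compound 3 in one place: azepan-1-yl in place of 3-phenylpyrrolidin-1-yl on an aromatic carbon.

Among the compounds with values here, two measured steps bear on this change. The step of a 3.6-fold higher number from compound 2 to compound 3 (0.56 log units; beyond the scatter) brought in the phenyl-bearing ring and the number rose; the step of a 13-fold higher number from compound 1 to compound 3 (1.10 log units; beyond the scatter) did the same from a smaller, open-chain amine and the number rose more strongly. Both point the same way: the phenyl-bearing group is the one feature that goes with a higher number. Azepan-1-yl carries no aromatic ring and is closer in size to the group of compound 2. The number for compound 4 is therefore expected to drop, by about a 5.1-fold lower number from compound 3 to compound 4 (0.70 log units; beyond the scatter). The estimate for compound 4 in this assay is 350 nM, with a range from 110 nM to 1100 nM.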

Compound 4, half-maximal effective concentration: 1800 nM
Estimate against measurement, compound 4: 5.1-fold (0.71 log units) below; the measured number lies above the stated range.
By their numbers in this assay, from the lowest: compound 1; then compound 2; then compounds 3 and 4 (each within the scatter of the next).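

In this assay, azepan-1-yl in place of 3-phenylpyrrolidin-1-yl on the aromatic carbon next to the ring nitrogen gives a 1.0-fold higher number from compound 3 to compound 4 (0.01 log units; within the scatter) and so shows that a group with no six-membered aromatic ring can sit level with compound 3. Size counted in heavy atoms does not settle the number either: the groups of compound 2 and compound 4 both have 7 heavy atoms, yet the step is a 3.7-fold higher number from compound 2 to compound 4 (0.57 log units; beyond the scatter) and goes with one seven-membered ring and 1 nitrogen replacing 2 five-membered rings and 2 nitrogen. Within the data shown here, the step of a 13-fold higher number from compound 1 to compound 4 (1.11 log units; beyond the scatter) leaves compound 1, the only compound here with an open-chain amine, with the lowest number of the four, while compound 2, whose amine is cyclic, lies beyond the scatter from it and from compounds 3 and 4 alike. Nothing measured here explains these differences. Still open, going by these compounds, is whether a simple piperidin-1-yl, a morpholin-4-yl or an open-chain diethylamino group would fall nearer compound 1 or nearer compound 4, which would tell whether the open chain itself goes with the lower number.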